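Swapping 3-Carboxyazetidin-1-yl for 3-Hydroxypyrrolidin-1-yl

This account rests on a few compounds, and the source may have more. Where it says the series, first, only, none or still open, it means among the compounds named here.

In a functional assay on HepG2 cells (Homo sapiens) for antiproliferative activity, read by CCK-8 assay, with a stated time of 48 h (a lower number here means a stronger inhibitor, a higher number a weaker inhibitor), compound 2 `COc1ccc(/C=C\c2cc(OC)c(OC)c(OC)c2)cc1OCc1ccc(CN2CC(C(=O)O)C2)cc1` gives > 10000 nM, which is a limit of the assay and not a number. Among the measured compounds shown here, compound 1 `COc1ccc(/C=C\c2cc(OC)c(OC)c(OC)c2)cc1OCc1ccc(CNC(C)(C)C(=O)O)cc1`, the only neighbour with a number, gives 6500 nM. Compound 3 `COc1ccc(/C=C\c2cc(OC)c(OC)c(OC)c2)cc1OCc1ccc(CN2CC[C@H](O)C2)cc1` carries 3-hydroxypyrrolidin-1-yl in place of 3-carboxyazetidin-1-yl on a saturated chain carbon bound to an aromatic carbon. For the measured compounds named here, the one measured step, an at least 1.5-fold higher number from compound 1 to compound 2 (0.18 log units; that floor lies within the scatter), has a floor within the scatter, and both of its compounds keep a carboxy group, so it offers only a weak guide. A moderate move toward stronger inhibition is expected, the estimated step being an at least 3.3-fold lower number from compound 2 to compound 3 (0.52 log units; beyond the scatter). For compound 3, the estimate is 3000 nM, with an expected range of 400 nM to 10000 nM.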

Compound 3, half-maximal inhibitory concentration: 6600 nM
Compound 3: middle estimate off by 2.2-fold (0.34 log units), on the low side; low and high end bracket the measured number.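

Compound 3 is the only one shown without a carboxy group, and in this assay the change from the open side chain reads a 1.0-fold higher number from compound 1 to compound 3 (0.01 log units; within the scatter), so a carboxy group is not needed for activity at this level. Leaving 3-carboxyazetidin-1-yl gives an at least 1.5-fold lower number from compound 2 to compound 3 (0.18 log units; that floor lies within the scatter), and the true size of that step stays unknown. Compound 2 stands at a limit of the assay, not a number: the limit of > 10000 nM in this assay, at which 1 of the 3 values shown sits.

Going by these compounds, whether the hydroxy group or its defined stereocentre matters stays open. So does how an unsubstituted pyrrolidine, a morpholine or a primary amine would read on this saturated chain carbon bound to an aromatic carbon.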